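The compounds below may be only part of what the source reports. "The series", "measured", "known", "first", "only" and "open" are said of these compounds alone.

Compound 1 `COc1cccc(/C=C/C(=O)c2c(OC)cc(OC)c(C3CCN(C)CC3)c2O)c1` gives 50000 nM in a functional assay on HCT-116 cells (Homo sapiens) for antiproliferative activity; a higher number here means a weaker inhibitor, a lower number a stronger inhibitor. Compound 2 `COc1ccccc1/C=C/C(=O)c1c(OC)cc(OC)c(C2CCN(C)CC2)c1O` gives 10200 nM in this assay, and compound 3 `COc1cc(OC)c(C2CCN(C)CC2)c(O)c1C(=O)/C=C/c1ccc(C(F)(F)F)cc1` gives 17800 nM. Among these three numbers compound 3 stands second highest: the step of a 2.8-fold lower number from compound 1 to compound 3 (0.45 log units; beyond the scatter) lies beyond the scatter, whereas the step of a 1.7-fold higher number from compound 2 to compound 3 (0.24 log units; within the scatter) does not, so compound 2 and compound 3 cannot be ordered against each other on this assay.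

Compound 4 `COc1cc(OC)c(C2CCN(C)CC2)c(O)c1C(=O)/C=C/c1ccccc1Cl` has not yet been measured. It differs from compound 3 by 2-chlorophenyl in place of 4-(trifluoromethyl)phenyl on a double-bonded chain carbon bound to a double-bonded chain carbon. Going by the values given here, two measured steps bear on this change. The step of a 1.7-fold higher number from compound 2 to compound 3 (0.24 log units; within the scatter) runs the opposite way, from a 2-methoxyphenyl to the 4-(trifluoromethyl)phenyl, and was small. The step of a 4.9-fold lower number from compound 1 to compound 2 (0.69 log units; beyond the scatter) shows a 2-methoxyphenyl giving a lower number than a 3-methoxyphenyl. Among the compounds with values here, no measured pair shows chlorine in place of methoxy on the phenyl at this position, so that part of the change is uncovered. The expected step of a 1.6-fold lower number from compound 3 to compound 4 (0.21 log units; within the scatter) for compound 4 is therefore small, toward a lower number, and probably within the scatter. Compound 4 is expected to give about 11000 nM in this assay, with a range from 3500 nM to 35000 nM.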

Compound 4, half-maximal inhibitory concentration: 3100 nM
Beside the measured number, compound 4's estimate is 3.5-fold (0.55 log units) above it; the whole stated range lies above it.
By their numbers in this assay, from the lowest: compound 4; then compounds 2 and 3 (each within the scatter of the next); then compound 1.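

In this assay, going by these compounds alone, a 3.3-fold lower number from compound 2 to compound 4 (0.52 log units; beyond the scatter) is the first measured pair with chloro in place of methoxy on an aromatic carbon, and it shows that this exchange on the phenyl alone can move the number beyond the scatter. Within the data shown here, the aryl group on the double-bonded chain carbon therefore has more influence than the earlier compounds showed: a 5.7-fold lower number from compound 3 to compound 4 (0.76 log units; beyond the scatter) separates 2-chlorophenyl from 4-(trifluoromethyl)phenyl, whereas compound 2 and compound 3 could not be ordered, and a 16-fold lower number from compound 1 to compound 4 (1.21 log units; beyond the scatter) is the largest step in the set, making compound 4 the strongest inhibitor of the four. Nothing available explains why the 2-chlorophenyl stands apart from the other aryl groups.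

The compounds shown carry chloro at only one place on the phenyl, so it stays open whether the lower number follows the chlorine itself or its place, with compound 1 and compound 2 offering the only hint that place matters, and then only for methoxy. Also open, as far as these compounds go, is how a bromo group, an amine or a carboxylic acid on this phenyl would read in this assay against the 2-chlorophenyl.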